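Ring Fluorine and Maximal Response in mGlu5 Modulators

This account rests on a few compounds, and the source may have more. Where it says the series, first, only, none or still open, it means among the compounds named here.

Three compounds sharing one core have been measured in a functional assay on HEK293 cells for positive allosteric modulation of metabotropic glutamate receptor 5 (Homo sapiens), read by calcium flux; a lower number here means a smaller maximal response, a higher number a larger maximal response:

compound 1, `O=C1c2cc(COc3ccccc3)nn2CCN1c1ccc(F)cc1`, gives 79%
compound 2, `O=C1c2cc(COc3ccccc3)nn2CCN1c1ccccn1`, gives 69%
compound 3, `O=C1c2cc(COc3ccccc3)nn2CCN1c1ccc(F)cn1`, gives 72%

The cores of compound 2 and compound 1 differ by 4-fluorophenyl in place of pyridin-2-yl on an amide-type nitrogen in a ring. In this assay this gives a number 10 percentage points lower from compound 1 to compound 2 (within the scatter), and the related change gives a number 7 percentage points lower from compound 1 to compound 3 (within the scatter). Between compound 2 and compound 3 the change is fluoro in place of hydrogen on an aromatic carbon, and the step is a number 3 percentage points higher from compound 2 to compound 3 (within the scatter).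

Compound 4, `O=C1c2cc(COc3ccccc3F)nn2CCN1c1ccc(F)cc1`, has not been measured. It differs from compound 1 by fluoro in place of hydrogen on an aromatic carbon. This is the same kind of change as from compound 2 to compound 3, not the same: there the fluoro enters a six-membered aromatic ring with 1 nitrogen, two atoms from the ring nitrogen, para to a large group, whereas here it enters a six-membered aromatic ring of carbon only, ortho to a large group.

The expected step is a number 1 percentage points lower from compound 1 to compound 4 (within the scatter), resting on the within-scatter a number 3 percentage points higher from compound 2 to compound 3 (within the scatter). Compound 4 is therefore estimated at 78%, expected between 64% and 92%.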

Compound 4, largest response reached (Emax), in percent of the reference or control that the assay uses: 66%
Compound 4: middle estimate off by 12 percentage points, on the high side; low and high end bracket the measured number.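

In this assay the exchange of phenoxy for 2-fluorophenoxy gives a number 13 percentage points lower from compound 1 to compound 4 (beyond the scatter) and this change of hydrogen to fluoro did not carry over unchanged from one compound pair to the other: the same change on two cores in this assay, a number 3 percentage points higher (within the scatter) from compound 2 to compound 3 and a number 13 percentage points lower (beyond the scatter) from compound 1 to compound 4, 16 percentage points apart, beyond the scatter of two such steps

The two steps differ in more than the core, however: in compound 4 the fluoro sits on a six-membered aromatic ring of carbon only, ortho to a large group, while in compound 3 it sits on a six-membered aromatic ring with 1 nitrogen, so the comparison does not separate the place of the fluoro from the core that carries it. With a single step on each side, the result shows that this change cannot be assumed to transfer within the series, but it does not show how the change would behave at any other place or on any other core.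

The compounds shown leave open whether the lower maximal response belongs to fluoro itself or to any group at that place on the phenoxy ring, which a chloro, a methyl or a methoxy group there could help to settle. They also leave open whether 2-fluorophenoxy on the cores of compound 2 and compound 3 would give a similar step.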